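Series notes: from compound 1 to compound 3

The source may report more compounds than this note shows. Statements on the series, on what has been measured and on what is new or still open speak of the compounds shown alone.

- Compound 1 `CC(C)NC(=O)[C@H]1CC[C@@H](n2/c(=N/C(=O)c3ccc(C#N)c(F)c3)[nH]c3ccc(CN4CCC(C(C)(C)O)CC4)cc32)CC1`: 29 mL.min-1.g-1
- Compound 2 `CC(C)NC(=O)[C@H]1CC[C@@H](n2/c(=N/C(=O)c3ccc(F)cc3)[nH]c3ccc(CN4CC(C(C)(C)O)C4)cc32)CC1`: < 14 mL.min-1.g-1 (a limit of the assay)

Both entries come from an in vitro ADME assay on microsomes from liver (Rattus norvegicus) for metabolic stability; a higher number here means faster removal of the compound, a lower number slower removal. Within the data shown here, compound 1 carries the only numeric value so far, at 29 mL.min-1.g-1. Compound 2 is reported at < 14 mL.min-1.g-1, which is a limit of the assay and not a number. Among the measured compounds shown here, the two compounds differ in more than one place, and no single-change step between measured compounds is available.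

Compound 3 `CC(C)NC(=O)[C@H]1CC[C@@H](n2/c(=N/C(=O)c3cccc(C#N)c3)[nH]c3ccc(CN4CCC(C(C)(C)O)CC4)cc32)CC1` keeps the core of compound 1 and changes one group, with 3-cyanophenyl in place of 4-cyano-3-fluorophenyl on a carbonyl carbon. The six-membered aromatic ring and the triple bond remain in the entering group, while the fluorine leaves.

For the measured compounds named here, with no measured step to draw on, the expectation starts from compound 1 at 29 mL.min-1.g-1 in this assay. The expected change is a 1.0-fold lower number from compound 1 to compound 3 (0.02 log units; within the scatter), which is no larger than the usual scatter and has no favoured direction. For compound 3 the estimate is 28 mL.min-1.g-1, with an expected range from 15 mL.min-1.g-1 to 55 mL.min-1.g-1.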

Compound 3, intrinsic clearance in microsomes: 17 mL.min-1.g-1
Compound 3: middle estimate off by 1.6-fold (0.22 log units), on the high side, within the range that was stated.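

Among these compounds, this is the first single-change step, and it sits on a carbonyl carbon whose other neighbour is the amide-type nitrogen: in this assay, 3-cyanophenyl in place of 4-cyano-3-fluorophenyl gives a 1.7-fold lower number from compound 1 to compound 3 (0.23 log units; within the scatter). On the core of compound 1, this place therefore accepts a change in which the fluorine leaves and the aromatic ring and nitrile remain, with no step beyond the scatter. Nothing shown gives a reason for the size of this step.

The group names also differ in the number given for the nitrile, and this one step cannot separate that difference from the loss of the fluorine; 4-cyanophenyl and 3-fluorophenyl at this place would each isolate one part of it. Also open, on these data alone, is how a saturated ring such as cyclohexyl, or a phenyl carrying a carboxylic acid, would read on the same core, and compound 2 differs from compound 1 in more than one place and gives no reading on this.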